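The source may report more compounds than this note shows. Statements on the series, on what has been measured and on what is new or still open speak of the compounds shown alone.

Three compounds share one core and differ only in the ring that sits on the thiocarbonyl carbon. In a functional assay on A-431 cells (Homo sapiens) for cytotoxicity, read by MTT assay, with a stated time of 72 h, tested at 30 uM (a lower number here means less inhibition of growth, a higher number more inhibition of growth at the concentration tested), compound 1 `N/C(=N\NC(=S)N1CCCCCC1)c1ccccn1` gives 72.3%, compound 3 `N/C(=N\NC(=S)N1CCCCC1)c1ccccn1` gives 79.7%, and compound 2 `N/C(=N\NC(=S)N1CCCC1)c1ccc(F)cn1` gives 83.3%. Compound 2 thus holds the highest of the three numbers; its gap to compound 3 lies within the usual scatter, while its gap to compound 1 lies beyond it. Compound 4 `N/C(=N\NC(=S)N1CCSCC1)c1ccc(F)cn1` has not yet been measured and carries thiomorpholin-4-yl in place of pyrrolidin-1-yl on a thiocarbonyl carbon. Among the measured compounds shown here, no measured pair separates these two rings, so the size of this change is unknown from the data. The expected step is small, none beyond the scatter, as a number 8.3 percentage points lower from compound 2 to compound 4 (within the scatter). Compound 4 is therefore estimated at 75%, within 58% to 90%, in this assay.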

Compound 4, percent growth inhibition at one concentration: 84.6%
Beside the measured number, compound 4's estimate is 9.6 percentage points below it; measured number inside the range.
By their numbers in this assay, from the lowest: compounds 1, 3, 2 and 4 (each within the scatter of the next, the first and the last beyond it).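

Among the compounds shown here, compound 2 and compound 4 are the first pair here that differ in only one place, so the ring on the thiocarbonyl carbon can now be judged on its own. In this assay, placing thiomorpholin-4-yl instead of pyrrolidin-1-yl there gives a number 1.3 percentage points higher from compound 2 to compound 4 (within the scatter), so this position accepts the change without a clear shift in growth inhibition. Nothing available explains this result. Still open, on these data alone, is whether morpholin-4-yl, with oxygen in the ring, or an open-chain diethylamino group would also hold the number at this position.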